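The compounds below may be only part of what the source reports. "The series", "measured", "known", "first", "only" and "open" are said of these compounds alone.

Compound 1 `COc1ncc(-c2ccc3nccc(C#CCN(C)C)c3c2)cc1NS(=O)(=O)c1ccc(F)cc1F`: in an assay on isolated protein for inhibition of phosphatidylinositol 4,5-bisphosphate 3-kinase catalytic subunit beta isoform (Homo sapiens), read by luminescence and ADP-Glo, with a stated time of 40 min, tested at 10 nM (on this read-out higher numbers stand for more inhibition at the one concentration tested (going by the name of the read-out) and lower numbers for less inhibition), compound 1 gives 41% 
Compound 2 `CCN(CC)CC#Cc1ccnc2ccc(-c3cnc(OC)c(NS(=O)(=O)c4ccc(F)cc4F)c3)cc12`: in this assay compound 2 gives 21% 
Compound 3 `COc1ncc(-c2ccc3nccc(C#CCN(C4CCCCC4)C4CCCCC4)c3c2)cc1NS(=O)(=O)c1ccc(F)cc1F`: in this assay compound 3 gives 13% 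

Compound 2 stands second of the three numbers; compound 3 lies within the scatter of it, while compound 1 sits higher, beyond the scatter. Compound 4 `COc1ncc(-c2ccc3nccc(C#CCN4CCCCC4)c3c2)cc1NS(=O)(=O)c1ccc(F)cc1F` differs from compound 2 by piperidin-1-yl in place of diethylamino on a saturated chain carbon bound to a triple-bonded carbon. Among the compounds with values here, the one step that bears on this place is a number 20 percentage points lower from compound 1 to compound 2 (beyond the scatter), a modest drop at the same chain carbon; compound 3, also varied there, shows a number within the scatter of compound 2. A further exchange of the amine is therefore expected to give no step beyond the scatter, a number 1 percentage points higher from compound 2 to compound 4 (within the scatter). Compound 4 is estimated at 22%, expected between 8% and 36%.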

Compound 4, a percentage reported as inhibition, at one concentration (the size of the read-out at that concentration, not a potency): 1.4%
Estimate against measurement, compound 4: 20.6 percentage points above; measured number below the stated range.
By their numbers in this assay, from the lowest: compound 4; then compounds 3 and 2 (each within the scatter of the next); then compound 1.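

In this assay, the step of a number 19.6 percentage points lower from compound 2 to compound 4 (beyond the scatter) shows that tying the diethylamino group into piperidin-1-yl is not a neutral exchange at this saturated chain carbon. The step of a number 39.6 percentage points lower from compound 1 to compound 4 (beyond the scatter) extends this: among compounds 1, 2 and 4, which differ only in this amine, dimethylamino gives the highest number. Nothing available accounts for the loss on ring closure. Open, from the compounds shown here alone, is whether pyrrolidin-1-yl or morpholin-4-yl would track piperidin-1-yl, and whether methylamino or an unsubstituted amino group would exceed dimethylamino. Single-concentration numbers also leave the potency of these compounds open.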